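Chloro added to the aryl ring of a dihydrotriazine

The source may hold more compounds than are shown below. What is called first, only, known or untested is meant among the compounds shown, and "the series" means these compounds.

Measured compounds:
compound 1 `CC1(C)N=C(N)N=C(N)N1c1cccc(OCCOc2ccc(S(=O)(=O)F)cc2)c1` – 7.82
compound 2 `CC1(C)N=C(N)N=C(N)N1c1ccc(OCc2c(Cl)cccc2S(=O)(=O)F)c(Cl)c1` – 7.72

Two compounds share the same core and a fluorosulfonyl-bearing aryl ether tail. In an assay on isolated protein for inhibition of Dihydrofolate reductase (Mus musculus) (on this read-out lower numbers stand for lower potency and higher numbers for higher potency (the scale is a negative logarithm)), compound 1 gives 7.82, and in this assay compound 2 gives 7.72. The two numbers lie within the usual scatter of each other, so neither can be set above the other. Among the measured compounds shown here, no single-point step between measured compounds is available.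

Compound 3 `CC1(C)N=C(N)N=C(N)N1c1ccc(Cl)c(OCCOc2ccc(S(=O)(=O)F)cc2)c1` has not yet been tested in this assay. It is derived from compound 1 by a single change: chloro in place of hydrogen on an aromatic carbon. The new group sits on an aromatic carbon of a six-membered aromatic ring of carbon only, ortho to a large group and para to a large group.

Since compound 2, which also carries chloro on its aryl rings, sits within the scatter of compound 1, the step in this assay from compound 1 to compound 3 is expected to be small, no more than the scatter, in either direction. Compound 3 is therefore estimated at 7.8, within the range 7.3 to 8.3, a change of a number 0.02 log units lower from compound 1 to compound 3 (within the scatter).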

Compound 3, logarithm of the reciprocal of the active concentration, log(1/C): 7.27
The estimate for compound 3 lay 0.53 log units above the measured number; measured number below the stated range.
By their numbers in this assay, from the lowest: compound 3; then compounds 2 and 1 (each within the scatter of the next).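

Chloro in place of hydrogen on an aromatic carbon, ortho to a large group and para to a large group, gives a number 0.55 log units lower from compound 1 to compound 3 (beyond the scatter) in this assay and is the only step here between compounds that differ in one place. This carbon therefore does not take the added chlorine without a loss of potency beyond the scatter, which could not be read from compound 1 and compound 2, as these two differ in more than one place. No measurement among the data accounts for the size or the direction of this step.

From the compounds shown here alone, what stays open is whether this loss belongs to chloro alone or would also follow from another group on the same carbon, such as fluoro, methyl or methoxy, and a hydroxyl or an amine there would widen that comparison. Also open, going by these compounds, is whether chloro would bring a similar step on the other aromatic carbons of this ring, or on this same carbon with a longer chain in place of the present tail of compound 1.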